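Sigma-1 receptor series: removing the amino group of compound 3

The source may report more compounds than this note shows. Statements on the series, on what has been measured and on what is new or still open speak of the compounds shown alone.

Measured so far:
compound 1 `N=C(Nc1cccc2ccccc12)N(c1ccccc1)c1cccc2ccccc12`: 7930 nM
compound 2 `Cc1cccc(N(C)C(=N)Nc2cccc3ccccc23)c1`: 1860 nM
compound 3 `CN(C(=N)Nc1cccc2ccccc12)c1cccc(N)c1`: 2700 nM

In an assay on membranes from brain (Cavia porcellus) for binding affinity to Sigma non-opioid intracellular receptor 1 (Homo sapiens), read by radioligand binding (on this read-out lower numbers stand for stronger inhibition and higher numbers for weaker inhibition), compound 3 stands second highest of the three numbers. Its nearest neighbour is compound 2, within the scatter; the furthest is compound 1, beyond it. Within the data shown here, the only single-point step recorded, a 1.5-fold higher number from compound 2 to compound 3 (0.16 log units; within the scatter), shows that swapping methyl for amino on the aromatic carbon left the read-out essentially unchanged.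

Compound 4 `CN(C(=N)Nc1cccc2ccccc12)c1ccccc1` carries the change (hydrogen in place of amino on an aromatic carbon), on an aromatic carbon of a six-membered aromatic ring of carbon only, meta to a large group. Among the measured compounds shown here, the one comparable step was within the scatter, so compound 4 is expected to show little movement, a 1.4-fold lower number from compound 3 to compound 4 (0.13 log units; within the scatter), if anything a slightly lower number. The estimate for compound 4 in this assay is 2000 nM, within 900 nM to 4500 nM.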

Compound 4, half-maximal inhibitory concentration: 2900 nM
Compound 4: the middle estimate sits 1.5-fold (0.16 log units) below what was measured, and the stated range covers the measured number.
By their numbers in this assay, from the lowest: compounds 2, 3 and 4 (each within the scatter of the next); then compound 1.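

In this assay, the change from 3-aminophenyl to phenyl gives a 1.1-fold higher number from compound 3 to compound 4 (0.03 log units; within the scatter) and the change from methyl to hydrogen gives a 1.6-fold higher number from compound 2 to compound 4 (0.19 log units; within the scatter), so amino, methyl and hydrogen on this aromatic carbon, meta to a large group, cannot be told apart. The nitrogen on an aromatic ring responds more clearly, with a 2.7-fold lower number from compound 1 to compound 4 (0.44 log units; beyond the scatter) for methyl in place of naphthalen-1-yl. Nothing available explains either result. Open, going by these compounds, is whether a carboxylic acid or a longer chain on this aromatic carbon would also leave the number in place. Also open, on these data alone, is how an ethyl group on that nitrogen would read.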